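The source may hold more compounds than are shown below. What is called first, only, known or untested is meant among the compounds shown, and "the series" means these compounds.

In a series sharing one core, compound 1 `Nc1ccccc1NC(=O)c1ccc(CSC(=S)N2CCN(c3ccc(F)cc3)CC2)cc1` carries a 4-fluorophenyl on the ring amine nitrogen and, in a functional assay on MGC-803 cells (Homo sapiens) for antiproliferative activity, read by CCK-8 assay, with a stated time of 72 h, tested at 8 uM (on this read-out higher numbers stand for a stronger effect at the one concentration tested and lower numbers for a weaker effect), compound 1 gives 48.7%. Compound 2 `Nc1ccccc1NC(=O)c1ccc(CSC(=S)N2CCN(C3CCCCC3)CC2)cc1` carries a cyclohexyl at the same place, and in this assay compound 2 gives 75.3%, the higher of the two numbers; the step of a number 26.6 percentage points higher from compound 1 to compound 2 (beyond the scatter) lies beyond the scatter. Compound 3 `Nc1ccccc1NC(=O)c1ccc(CSC(=S)N2CCN(Cc3ccccc3)CC2)cc1` differs from compound 2 only by benzyl in place of cyclohexyl on an amine nitrogen in a ring. Within the data shown here, no measured step covers this exact exchange; the only step in hand, a number 26.6 percentage points higher from compound 1 to compound 2 (beyond the scatter), shows that an aromatic ring directly on that nitrogen ran lower than the saturated ring. Benzyl brings an aromatic ring back, though not directly on the nitrogen, so a modest fall is expected, a number 13.3 percentage points lower from compound 2 to compound 3 (beyond the scatter). Compound 3 is estimated at 62%, within 45% to 80%.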

Compound 3, a percentage reported as inhibition, at one concentration (the size of the read-out at that concentration, not a potency): 19.7%
Beside the measured number, compound 3's estimate is 42.3 percentage points above it; measured number below the stated range.
By their numbers in this assay, from the lowest: compound 3; then compound 1; then compound 2.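

In this assay, the exchange gives a number 55.6 percentage points lower from compound 2 to compound 3 (beyond the scatter), so moving the aromatic ring off the ring nitrogen with benzyl did not bring the number closer to that of the saturated cyclohexyl. Benzyl also falls short of the directly attached 4-fluorophenyl, with a number 29 percentage points lower from compound 1 to compound 3 (beyond the scatter), so among these three compounds both aromatic groups run lower than cyclohexyl, and the one set further from the nitrogen runs lowest. No measurement given here explains why this position responds so strongly to the exchange.

Compound 1 and compound 3 differ both in the fluorine and in the carbon linking the ring, so their step does not separate these two changes. An unsubstituted phenyl, a 4-fluorobenzyl or a cyclohexylmethyl group would leave open how each of them contributes.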